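Shifting the alkoxy group on the aniline ring

A few compounds are considered here, and "the series" means these few. Any claim that something is new, unique, unknown or untested is made for them only; others in the source may bear on it.

Compound 2, `COc1ccc(Nc2nc3nonc3nc2Nc2ccccc2F)cc1`, gives 1600 nM in an assay on mitochondria from L6 cells (Rattus norvegicus) for activation, with a stated time of 90 min (a lower number here means that less compound is needed, a higher number that more compound is needed for the effect), the highest of the two numbers recorded so far. For the measured compounds named here, its only measured neighbour is compound 1, `Fc1ccc(Nc2nc3nonc3nc2Nc2ccccc2F)c(F)c1`, which bears 2,4-difluorophenyl on the same nitrogen and gives 300 nM; the step of a 5.3-fold higher number from compound 1 to compound 2 (0.73 log units; beyond the scatter) is the single piece of evidence on how this aryl group matters. Compound 3, `CCOc1ccccc1Nc1nc2nonc2nc1Nc1ccccc1F`, carries the change (2-ethoxyphenyl in place of 4-methoxyphenyl on a nitrogen on an aromatic ring). Going by the values given here, no measured step covers a 2-ethoxyphenyl group, so the only guide is that compound 1, with fluorine in the 2-position of its ring, gave the lower number. Compound 3 is therefore expected to land with a step of a 2.3-fold lower number from compound 2 to compound 3 (0.36 log units; beyond the scatter), a moderate improvement in this assay. Compound 3 is estimated at 700 nM, with a range from 200 nM to 2500 nM.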

Compound 3, half-maximal effective concentration: 5600 nM
Compound 3: the middle estimate sits 8.0-fold (0.90 log units) below what was measured; measured number outside the range, above it.
By their numbers in this assay, from the lowest: compound 1; then compound 2; then compound 3.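

In this assay, moving from 4-methoxyphenyl to 2-ethoxyphenyl on this nitrogen raises the number needed (a 3.5-fold higher number from compound 2 to compound 3 (0.54 log units; beyond the scatter)), so a substituent in the 2-position of the ring brings no gain when it is ethoxy rather than fluorine. The gap to the 2,4-difluorophenyl group is large (a 19-fold higher number from compound 1 to compound 3 (1.27 log units; beyond the scatter)), and both alkoxy-bearing rings now give higher numbers than that fluorinated ring, which makes this aryl group a clear driver of the number among these three compounds. No measurement is available that would explain why the change acts this way.

Because this step alters both the place and the length of the alkoxy group, the compounds shown cannot separate the two changes. On these data alone, a 2-methoxyphenyl or 4-ethoxyphenyl group would be needed to do so, and how a ring bearing an amine or a carboxylic acid would behave on this nitrogen remains open.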